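NAMPT activator series: sulfonamide urea, benzyl to methyl

The compounds below may be only part of what the source reports. "The series", "measured", "known", "first", "only" and "open" are said of these compounds alone.

Measured compounds:
- compound 1 `CN(Cc1ccccc1)S(=O)(=O)c1ccc(NC(=O)NCc2ccncc2)cc1`: 23 nM
- compound 2 `CCOC(=O)c1ccc(N/C(=N\C#N)NCc2ccncc2)cc1`: 41400 nM
- compound 3 `O=C(NCc1cnco1)Nc1ccc(S(=O)(=O)c2cccc(OC(F)(F)F)c2)cc1`: 70 nM

In an assay on isolated protein for activation of Nicotinamide phosphoribosyltransferase (Homo sapiens) (a higher number here means that more compound is needed for the effect, a lower number that less compound is needed), compound 1 gives 23 nM, the lowest of the three numbers. The nearest is compound 3 with 70 nM, a gap beyond the scatter, and the furthest is compound 2 with 41400 nM, the cyanoguanidine ester that stands far apart from the two ureas.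

Compound 4 `CN(C)S(=O)(=O)c1ccc(NC(=O)NCc2ccncc2)cc1` is not yet measured in this assay. It differs from compound 1 in one place: hydrogen in place of phenyl on a saturated chain carbon bound to a sulfonamide nitrogen. Cut one bond further out, the change reads benzyl to methyl, benzyl(methyl)amino to dimethylamino.

Among the measured compounds shown here, no pair of measured compounds differs in a single place, so no measured step guides the size of this change. Removing a phenyl from the sulfonamide substituent of compound 1 is expected to raise the number, by a moderate step that lies beyond the scatter. The step from compound 1 to compound 4 is estimated at a 4.8-fold higher number from compound 1 to compound 4 (0.68 log units; beyond the scatter). Compound 4 is expected to give about 110 nM in this assay, within a range of 30 nM to 450 nM.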

Compound 4, half-maximal effective concentration: 3110 nM
Beside the measured number, compound 4's estimate is 28-fold (1.45 log units) below it; the whole stated range lies below it.
By their numbers in this assay, from the lowest: compound 1; then compound 3; then compound 4; then compound 2.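

In this assay, among the compounds shown here, replacing benzyl with methyl gives a 140-fold higher number from compound 1 to compound 4 (2.13 log units; beyond the scatter) and is the only step that changes a single place. The sulfonamide substituent of compound 1 is therefore a position where removing the phenyl has a large effect on the number, with the rest of the structure unchanged. No available data bear on the reason for the size of this step.

The compounds shown leave open whether the full phenyl is needed, since ethyl, cyclohexylmethyl or phenethyl in place of benzyl would separate the ring from the chain that carries it. Also open, on these data alone, is how far the phenyl tolerates added groups, such as a chlorine or a methoxy.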